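Swapping the aryl group on a sulfonamide nitrogen

A few compounds are considered here, and "the series" means these few. Any claim that something is new, unique, unknown or untested is made for them only; others in the source may bear on it.

In a functional assay on cells (leukaemia cell line, Homo sapiens) for inhibition, read by sulforhodamine B assay, with a stated time of 48 h (on this read-out lower numbers stand for stronger inhibition of growth and higher numbers for weaker inhibition of growth), compound 1 (`O=S(=O)(Nc1ccc(Br)c(Cl)c1)c1ccc(-c2cnc(C3CC3)o2)cc1`) gives 70300 nM and compound 2 (`COc1cc(NS(=O)(=O)c2ccc(-c3cnc(C4CC4)o3)cc2)ccc1F`) gives 75700 nM on the same read-out, so compound 2 stands within the scatter of compound 1. Compound 3 (`O=S(=O)(Nc1ccc(I)c(Cl)c1)c1ccc(-c2cnc(C3CC3)o2)cc1`) differs from compound 2 by 3-chloro-4-iodophenyl in place of 4-fluoro-3-methoxyphenyl on a sulfonamide nitrogen on a sulfonamide nitrogen. Going by the values given here, the only measured change at that place (a 1.1-fold higher number from compound 1 to compound 2 (0.03 log units; within the scatter)) stayed within the scatter, so no shift beyond the scatter is expected here. The estimated step (a 1.1-fold lower number from compound 2 to compound 3 (0.03 log units; within the scatter)) is accordingly small. Compound 3 is expected at 70000 nM (estimated range 38000 nM to 115000 nM).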

Compound 3, concentration for total growth inhibition: 19600 nM
Beside the measured number, compound 3's estimate is 3.6-fold (0.55 log units) above it; measured number outside the range, below it.
By their numbers in this assay, from the lowest: compound 3; then compounds 1 and 2 (each within the scatter of the next).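

The aryl group on the sulfonamide nitrogen can move the number in this assay after all: the earlier swap stayed within the scatter, whereas this one gives a 3.9-fold lower number from compound 2 to compound 3 (0.59 log units; beyond the scatter). Going by these compounds alone, the single exchange of iodo in place of bromo on an aromatic carbon gives a 3.6-fold lower number from compound 1 to compound 3 (0.55 log units; beyond the scatter), so changing that one atom is enough to produce a shift beyond the scatter. Nothing available explains this shift. As far as these compounds go, whether an amine or a trifluoromethyl group in place of the iodo would keep the lower number remains open, as does what the chloro group contributes.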